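The source may hold more compounds than are shown below. What is called first, only, known or untested is meant among the compounds shown, and "the series" means these compounds.

In a functional assay on SGC-7901 cells (Homo sapiens) for antiproliferative activity, read by MTT assay, with a stated time of 72 h (on this read-out higher numbers stand for weaker inhibition and lower numbers for stronger inhibition), compound 1 `CCOc1ccc(-c2ccc3ncn(-c4cc(OC)c(OC)c(OC)c4)c3c2)cc1` gives 2970 nM, compound 3 `COc1cc(-n2cnc3ccc(-c4ccc(C)cc4F)cc32)cc(OC)c1OC` gives 5650 nM, and compound 2 `COc1cc(-n2cnc3ccc(-c4ccc(C(C)=O)cc4)cc32)cc(OC)c1OC` gives 450 nM, the lowest of the three numbers. Compound 4 `COc1ccc(-c2ccc3ncn(-c4cc(OC)c(OC)c(OC)c4)c3c2)cc1O` departs from compound 2 at one aromatic carbon: 3-hydroxy-4-methoxyphenyl in place of 4-acetylphenyl on an aromatic carbon. Among the measured compounds shown here, three measured steps concern this place: a 6.6-fold lower number from compound 1 to compound 2 (0.82 log units; beyond the scatter), a 13-fold higher number from compound 2 to compound 3 (1.10 log units; beyond the scatter) and a 1.9-fold higher number from compound 1 to compound 3 (0.28 log units; within the scatter). For the measured compounds named here, the first two show that swaps here can move the number well beyond the scatter, while the third does not. Going by the values given here, no measured compound carries a hydroxy group, so the direction in this assay stays open and no step beyond the scatter is expected. The expected step is a 1.3-fold lower number from compound 2 to compound 4 (0.11 log units; within the scatter). For compound 4 the estimate is 350 nM, with an expected range of 40 nM to 3000 nM.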

Compound 4, half-maximal inhibitory concentration: 44 nM
For compound 4 the middle estimate is 8.0-fold (0.90 log units) above the measured one, and the stated range covers the measured number.
By their numbers in this assay, from the lowest: compound 4; then compound 2; then compounds 1 and 3 (each within the scatter of the next).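

In this assay the 3-hydroxy-4-methoxyphenyl group stands apart from all three earlier groups at this aromatic carbon: a 10-fold lower number from compound 2 to compound 4 (1.01 log units; beyond the scatter), a 68-fold lower number from compound 1 to compound 4 (1.83 log units; beyond the scatter) and a 130-fold lower number from compound 3 to compound 4 (2.11 log units; beyond the scatter). Compound 4 therefore displaces compound 2 as the most potent of the four, so 4-acetylphenyl no longer marks the best result here. No measurement available here explains this gain. Still open, going by these compounds, is whether the hydroxy group or the methoxy group carries the gain, and whether an amine or a carboxylic acid in place of the hydroxy group would keep it.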